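Amine substitution on the shared core: working notes

The source may hold more compounds than are shown below. What is called first, only, known or untested is meant among the compounds shown, and "the series" means these compounds.

Compound 1 `CC1(C)CC(N)=Nc2ccc(Cl)cc21` carries an unsubstituted amine on the shared core. Among the compounds with values here, in a functional assay on MDA-MB-231 cells (Homo sapiens) for cytotoxicity, read by MTT assay, with a stated time of 72 h, tested at 5 uM, in the absence of a further agent (on this read-out lower numbers stand for a stronger effect and higher numbers for a weaker effect at the one concentration tested), compound 1 gives 81%, the lowest of the three numbers measured so far. Compound 2 `CNC1=Nc2ccc(Cl)cc2C(C)(C)C1` gives 92.3% in this assay, and compound 3 `CC1(C)CC(NCCCCO)=Nc2ccc(Cl)cc21` gives 84.9% in this assay. Both measured steps from compound 1 replace hydrogen on the amine nitrogen with a carbon substituent: a number 11.3 percentage points higher from compound 1 to compound 2 (beyond the scatter), and a number 3.9 percentage points higher from compound 1 to compound 3 (within the scatter). Compound 4 `CN(C)CCCNC1=Nc2ccc(Cl)cc2C(C)(C)C1` is reached from compound 1 by 3-(dimethylamino)propyl in place of hydrogen on an amine nitrogen. The two steps from compound 1 that bear on this change point the same way, one beyond the scatter and one within it, so in this assay a modest step toward a higher number, or none beyond the scatter, is expected for compound 4. The estimated step is a number 6 percentage points higher from compound 1 to compound 4 (within the scatter). For compound 4 a value of 87% is expected, with a range from 76% to 97%.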

Compound 4, a percentage reported as activity, at one concentration (the size of the read-out at that concentration, not a potency): 38%
The estimate for compound 4 lay 49 percentage points above the measured number; the whole stated range lies above it.
By their numbers in this assay, from the lowest: compound 4; then compounds 1, 3 and 2 (each within the scatter of the next, the first and the last beyond it).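

In this assay, within the data shown here, the amine nitrogen of the shared core is no longer a place where substitution only leaves the number unchanged within the scatter or raises it: 3-(dimethylamino)propyl in place of hydrogen gives a number 43 percentage points lower from compound 1 to compound 4 (beyond the scatter) and is the only change from compound 1 here that gives a lower number. A chain on this nitrogen is not enough by itself, as the exchange at its end, dimethylamino in place of hydroxymethyl, gives a number 46.9 percentage points lower from compound 3 to compound 4 (beyond the scatter), and the comparison with the methyl group gives a number 54.3 percentage points lower from compound 2 to compound 4 (beyond the scatter). No measurement available here accounts for this drop.

Still open, from the compounds shown here alone, is whether the terminal dimethylamino group must be kept as it stands, or whether a primary amine, a piperidine or a carboxylic acid at the chain end would give a similar number. Going by these compounds, it is also open how a shorter or longer chain carrying the same dimethylamino group would read.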